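The source may hold more compounds than are shown below. What is called first, only, known or untested is meant among the compounds shown, and "the series" means these compounds.

Measured so far:
compound 1 `COc1ccc(-c2nc(C)c(C(=O)CSc3nc(-c4cccc(OC)c4)c(C#N)c(=O)[nH]3)s2)cc1`, 12.4%
compound 2 `Cc1nc(-c2ccc(Cl)cc2)sc1C(=O)CSc1nc(-c2ccc(Cl)c(Cl)c2)c(C#N)c(=O)[nH]1`, 36.5%

In a functional assay on U-87MG ATCC cells for antiproliferative activity against U-87 MG (Homo sapiens), read by MTT assay, with a stated time of 48 h, tested at 100 uM (a higher number here means a weaker effect of the compound at the concentration tested, a lower number a stronger effect), compound 2 gives 36.5%, the highest of the two numbers. Compound 1 gives 12.4%, a number lower by more than the scatter. Compound 3 `COc1ccc(-c2nc(C)c(C(=O)CSc3nc(-c4ccc(Cl)c(Cl)c4)c(C#N)c(=O)[nH]3)s2)cc1` is not yet measured; it differs from compound 2 in one place: methoxy in place of chloro on an aromatic carbon. Among the compounds with values here, no measured pair shows this change alone, so the size of the step is uncertain; compound 1, which carries methoxy groups, gives 12.4%. A modest step down is expected, a number 10.5 percentage points lower from compound 2 to compound 3 (beyond the scatter). Compound 3 is estimated at 26%, within 10% to 45%.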

Compound 3, a percentage reported as activity, at one concentration (the size of the read-out at that concentration, not a potency): 31.1%
For compound 3 the middle estimate is 5.1 percentage points below the measured one; the range from low to high includes it.
By their numbers in this assay, from the lowest: compound 1; then compounds 3 and 2 (each within the scatter of the next).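

In this assay, methoxy in place of chloro on this aromatic carbon, para to a large group, gives a number 5.4 percentage points lower from compound 2 to compound 3 (within the scatter), so the swap from 4-chlorophenyl to 4-methoxyphenyl separates nothing here. With 4-methoxyphenyl held fixed, 3,4-dichlorophenyl in place of 3-methoxyphenyl gives a number 18.7 percentage points higher from compound 1 to compound 3 (beyond the scatter), so among these compounds only that other place moves the number. Nothing measured accounts for either step. On these data alone, whether an amine or a carboxylic acid on this carbon would behave like chloro and methoxy remains open. So does whether the chloro-to-methoxy step reads the same alongside 3-methoxyphenyl.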